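Swapping a Branched Chain for a Fluorophenyl Ring

A few compounds are considered here, and "the series" means these few. Any claim that something is new, unique, unknown or untested is made for them only; others in the source may bear on it.

Measured so far:
compound 1, `O=C(/C(=C/c1ccc(Cl)cc1)CCl)c1ccccc1`: 22000 nM
compound 2, `CCC(/C=C(\COC(C)=O)C(=O)c1ccccc1)CC`: 50000 nM

In a functional assay on HeLa cells (Homo sapiens) for inhibition, read by sulforhodamine B assay, with a stated time of 48 h (a lower number here means a stronger inhibitor of growth, a higher number a weaker inhibitor of growth), compound 1 gives 22000 nM and compound 2 gives 50000 nM. Compound 2 therefore carries the higher of the two numbers, marking it as the weaker growth inhibitor of the pair, and its gap to compound 1 lies beyond the usual scatter of this assay. Compound 3, `CC(=O)OC/C(=C\c1ccccc1F)C(=O)c1ccccc1`, is not yet measured. The change from compound 2 to compound 3 is 2-fluorophenyl in place of pentan-3-yl on a double-bonded chain carbon bound to a double-bonded chain carbon. For the measured compounds named here, no step between two measured compounds tracks this change, so any expectation rests on the observation that compound 1, which also carries an aromatic ring on that chain carbon, gives 22000 nM in this assay. On that basis the step of a 2.0-fold lower number from compound 2 to compound 3 (0.30 log units; within the scatter) is expected to be a modest lowering of the number. Compound 3 is estimated at 25000 nM in this assay, with a range from 8000 nM to 70000 nM.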

Compound 3, concentration for 50% growth inhibition: 22000 nM
Compound 3: the middle estimate sits 1.1-fold (0.06 log units) above what was measured; the range from low to high includes it.
By their numbers in this assay, from the lowest: compounds 1 and 3 (each within the scatter of the next); then compound 2.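

Putting 2-fluorophenyl in place of pentan-3-yl on this double-bonded chain carbon gives a 2.3-fold lower number from compound 2 to compound 3 (0.36 log units; beyond the scatter) in this assay. For the compounds shown here, this is the first direct one-place comparison at this position, and it shows that the number responds to the group placed there, with the aromatic ring giving the lower number of the two. The step is modest, however, and nothing shown here explains it.

The change swaps a branched chain for a ring and adds fluorine in a single move, so the contribution of the fluorine cannot be separated from that of the ring. A plain phenyl ring would make that separation, while a phenyl ring carrying an amine or a longer straight chain would show how much further the number can move at this position.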